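The source may hold more compounds than are shown below. What is called first, only, known or untested is meant among the compounds shown, and "the series" means these compounds.

Measured so far in an assay on isolated protein (Mus musculus) for inhibition of IL15-IL15 receptor (Homo sapiens), read by resazurin assay, with stated times of 30 min and 2.5 days; on this read-out lower numbers stand for stronger inhibition and higher numbers for weaker inhibition:
compound 1 `CCCOc1ccc(NC(=O)CCCCCCCSc2nnc(Cc3nn(C)c(=O)c4ccccc34)n2C)cc1` gives 1600 nM
compound 2 `Cn1c(Cc2nn(C)c(=O)c3ccccc23)nnc1SCC(=O)Nc1ccc(O)cc1` gives "not active" (no number reported)
compound 3 `Cn1c(Cc2nn(C)c(=O)c3ccccc23)nnc1S(=O)(=O)CCCCCCCC(=O)Nc1ccc(Br)cc1Br` gives 1400 nM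

Compound 1 holds the higher of the two numbers recorded, with compound 3 lying within the usual scatter of it; compound 2 returned no number at all. Compound 4 `Cn1c(Cc2nn(C)c(=O)c3ccccc23)nnc1SCCCCCCCC(=O)Oc1ccc(Cl)cc1Cl` differs from compound 1 in one place: 2,4-dichlorophenoxy in place of (4-propoxyphenyl)amino on a carbonyl carbon. Going by the values given here, no pair of measured compounds spans this change, so nothing measured fixes its size. The expectation for the step from compound 1 to compound 4 in this assay is a 1.4-fold higher number from compound 1 to compound 4 (0.14 log units; within the scatter), a move toward weaker inhibition but not clearly beyond the scatter. Compound 4 is estimated at 2200 nM, with a range from 700 nM to 7000 nM.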

Compound 4, half-maximal inhibitory concentration: 800 nM
Beside the measured number, compound 4's estimate is 2.8-fold (0.44 log units) above it; the measured number falls inside the stated range.
By their numbers in this assay, from the lowest: compounds 4, 3 and 1 (each within the scatter of the next).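

In this assay, the carbonyl carbon carries 2,4-dichlorophenoxy in place of (4-propoxyphenyl)amino with a 2.0-fold lower number from compound 1 to compound 4 (0.30 log units; within the scatter), so this position accepts an exchange of the whole group, including loss of the hydrogen-bond donor, without a change beyond the scatter. Nothing available explains the size of this step. Compound 4 changes the linking atom and the ring substituents together, so their separate contributions cannot be read. Also open, from the compounds shown here alone, is whether a carboxylic acid or a piperidine amide at this carbonyl carbon keeps inhibition in this range.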